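The source may report more compounds than this note shows. Statements on the series, on what has been measured and on what is new or still open speak of the compounds shown alone.

Measured so far in a physicochemical assay for solubility, read by HPLC, in phosphate buffer, measured as kinetic solubility, at pH 7.4; a lower number here means a less soluble compound, a higher number a more soluble compound:

- Compound 1 `CCOC(=O)c1cc(-c2ccc(Cl)cc2)n(-c2ccc(S(N)(=O)=O)cc2)c1C`: 4200 nM
- Compound 2 `CCOC(=O)c1cc(-c2ccc(OC)cc2)n(-c2ccc(S(N)(=O)=O)cc2)c1C`: 16100 nM
- Compound 3 `CCOC(=O)c1cc(-c2cccc(Cl)c2)n(-c2ccc(S(N)(=O)=O)cc2)c1C`: 9200 nM

Compound 3, at 9200 nM, stands clear of compound 1, with a 2.2-fold higher number from compound 1 to compound 3 (0.34 log units; beyond the scatter), while a 1.8-fold lower number from compound 2 to compound 3 (0.24 log units; within the scatter) keeps it level with compound 2. Compound 4 `Cc1c(C(=O)O)cc(-c2cccc(Cl)c2)n1-c1ccc(S(N)(=O)=O)cc1` turns the ethoxycarbonyl of compound 3 into carboxy: hydrogen in place of ethyl on an oxygen next to a carbonyl group. The modest steps of a 3.8-fold higher number from compound 1 to compound 2 (0.58 log units; beyond the scatter) and a 2.2-fold higher number from compound 1 to compound 3 (0.34 log units; beyond the scatter) both alter the aromatic substituent, and neither touches the ethoxycarbonyl. For the measured compounds named here, they therefore offer only a loose guide to size, and no measured pair shows this change. In this assay, a rise well beyond those steps is expected. The expected change is a 13-fold higher number from compound 3 to compound 4 (1.12 log units; beyond the scatter). For compound 4 the estimated value is 120000 nM, with an expected range of 30000 nM to 400000 nM.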

Compound 4, solubility: 100000 nM
Beside the measured number, compound 4's estimate is 1.2-fold (0.08 log units) above it, and the stated range covers the measured number.
By their numbers in this assay, from the lowest: compound 1; then compounds 3 and 2 (each within the scatter of the next); then compound 4.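

In this assay, for the compounds shown here, swapping ethyl for hydrogen on the oxygen of the ethoxycarbonyl gives the first measured change at this position, and the step is large (an 11-fold higher number from compound 3 to compound 4 (1.04 log units; beyond the scatter)). It far outstrips the changes to the aromatic substituent (a 3.8-fold higher number from compound 1 to compound 2 (0.58 log units; beyond the scatter)), so in this small set, this position moves the number more than those aromatic changes do. Nothing measured here explains the jump. The change is shown only on the 3-chlorophenyl compound, so its size with 4-chlorophenyl or 4-methoxyphenyl remains open. Also open, from the compounds shown here alone, is where a methyl ester or a primary amide in the same place would fall.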